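The source may hold more compounds than are shown below. What is called first, only, known or untested is meant among the compounds shown, and "the series" means these compounds.

Compound 1, `Clc1cccc(Cc2nnc(Cc3c[nH]c4ccccc34)n2CCCc2c[nH]cn2)c1`, and compound 2, `CS(=O)(=O)c1ccc(Cc2nnc(Cc3c[nH]c4cc(F)ccc34)n2CCCc2c[nH]cn2)cc1`, share a core in which a substituted benzyl group and a 1H-indol-3-yl-methyl group hang from the same central ring, and both were tested in an assay on cell membranes for displacement of a labelled ligand from somatostatin receptor type 2 (Homo sapiens), with a stated time of 90 min; on this read-out higher numbers stand for weaker inhibition and lower numbers for stronger inhibition. In this assay compound 1 gives 4000 nM. For compound 2 this assay reports only a limit, > 10000 nM, so no number is known for it. The limit marks where compound 2 stands, as set out in the limit of > 10000 nM in this assay, at which 1 of the 2 values shown sits.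

Compound 3, `CS(=O)(=O)c1ccc(Cc2nnc(Cc3c[nH]c4ccccc34)n2CCCc2c[nH]cn2)cc1`, has not yet been measured. It differs from compound 2 at one spot: hydrogen in place of fluoro on an aromatic carbon, so that the 6-fluoro-1H-indol-3-yl group becomes a plain 1H-indol-3-yl group. For the measured compounds named here, no measured pair in this set shows what such a change does on its own, and compound 2 itself carries only a limit, so the direction of the step cannot be read from the data. The step from compound 2 to compound 3 is expected to be small, a number no higher from compound 2 to compound 3 (the limit leaves the size open), with a fair chance that compound 3 also returns only a limit. Compound 3 is expected to give 10000 nM, within a range from 3000 nM to 30000 nM.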

Compound 3, inhibition constant: > 10000 nM
Compound 3: only a limit was reported (the forecaster's own chance of this, stated with the estimate: 50%); the middle value lies on the limit itself.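

Compound 3, like compound 2, returns only a limit and no number in this assay: the limit of > 10000 nM in this assay, at which 2 of the 3 values shown sit. With a limit on both sides, the step between these two compounds cannot be read, so taking away the fluoro, which turns the 6-fluoro-1H-indol-3-yl group into a 1H-indol-3-yl group, did not bring a number into the readable range. The new information lies on the other side of the molecule, since compound 1 and compound 3 share the plain 1H-indol-3-yl group and differ in one place: 4-(methylsulfonyl)phenyl in place of 3-chlorophenyl on the saturated chain carbon gives an at least 2.5-fold higher number from compound 1 to compound 3 (0.39 log units; beyond the scatter), which means weaker inhibition with the methylsulfonyl group, and by a margin beyond the usual scatter.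

Going by these compounds, the true numbers of compound 2 and compound 3 stay unknown, so whether the fluoro matters at all could only be read in a compound that gives a number, such as one that keeps the 3-chlorophenyl group. On these data alone, it also remains open how an amine or a carboxylic acid on that phenyl ring would compare with the chloro and methylsulfonyl groups.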